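The source may report more compounds than this note shows. Statements on the series, on what has been measured and on what is new or still open speak of the compounds shown alone.

Working notes on the series.

Compound 1 `Cc1nn(-c2ccccc2)c(Oc2ccc(-c3nc4cc(C(=O)O)ccc4[nH]3)cc2)c1/C=N/NC(N)=S` and compound 3 `Cc1nn(-c2ccccc2)c(Oc2ccc(-c3nc4cc(C(N)=O)ccc4[nH]3)cc2)c1/C=N/NC(N)=S` share one core; compound 2 `Cc1nn(-c2ccccc2)c(Sc2ccc(-c3nc4cc(C(=O)O)ccc4[nH]3)cc2)c1/C=N/NC(N)=O` and the unmeasured compound 4 `Cc1nn(-c2ccccc2)c(Sc2ccc(-c3nc4cc(C(N)=O)ccc4[nH]3)cc2)c1/C=N/NC(N)=O` share another, and the difference between the two cores is not broken down here. In a functional assay on MCF7 cells (Homo sapiens) for cytotoxicity, read by sulforhodamine B assay, with a stated time of 48 h, in the presence of a further agent that is not named here (a higher number here means a weaker inhibitor of growth, a lower number a stronger inhibitor of growth), compound 1 gives only a limit, > 100000 nM. In this assay compound 3 likewise gives only a limit, > 100000 nM. Among the measured compounds shown here, compound 2 is the one compound with a number here; in this assay compound 2 gives 60 nM.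

The change from compound 1 to compound 3 is amino in place of hydroxy on a carbonyl carbon, and the step it made, a step that the two limits leave unreadable from compound 1 to compound 3, cannot be read, since both ends sit at the limit of > 100000 nM in this assay, at which 2 of the 3 values shown sit. The change from compound 2 to compound 4 is the same change, (amino in place of hydroxy on a carbonyl carbon), made on the other core: the place lines read alike word for word. So the pair of compound 1 and compound 3 gives no size for this change, and nothing else in the set shows the carboxy to carbamoyl exchange with a readable number on either side.

What is expected for compound 4 therefore rests on compound 2 alone, with 60 nM as the anchor, and an exchange of one donor group for another of matching count. The expected step from compound 2 to compound 4 in this assay is a 2.5-fold higher number from compound 2 to compound 4 (0.40 log units; beyond the scatter), kept modest for want of a measured precedent. Compound 4 is estimated at 150 nM, with a range from 30 nM to 2000 nM.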

Compound 4, concentration for 50% growth inhibition: > 100000 nM
Compound 4 ended at the assay's limit; the forecaster's own chance of this, stated with the estimate: 10%; middle value at least 660-fold (2.82 log units) from the limit.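

In this assay compound 4 gives > 100000 nM, which is a limit of the assay and not a number. As far as these compounds go, on the core of compound 2, amino in place of hydroxy on a carbonyl carbon produces an at least 1600-fold higher number from compound 2 to compound 4 (3.22 log units; beyond the scatter), so on this core the carboxy to carbamoyl exchange is far from neutral, and the true size of the step remains open at its upper end. This does not show that the change carries from one core to another, since the same exchange on the core of compound 1 cannot be read and the series offers only one readable instance of it, with the other three compounds' results reducing to a single shared ceiling: the limit of > 100000 nM in this assay, at which 3 of the 4 values shown sit.

Among the compounds shown here, still open is whether the carboxy group is the only group on this position of the core of compound 2 that keeps a measured number, or whether a methyl ester, a nitrile or a hydroxymethyl group would do the same. Also open is which part of the difference between the two cores separates compound 1 from compound 2, as the compounds shown do not split that difference into single changes.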